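Formyl in place of acetyl on a shared coumarin-free core

This account rests on a few compounds, and the source may have more. Where it says the series, first, only, none or still open, it means among the compounds named here.

Measured so far:
compound 1, `CCNC(=O)Nc1cc(=O)oc2cc(OCc3cccc(Cl)c3)ccc12`, 0%
compound 2, `CC(=O)c1cc(=O)oc2cc(OCc3cccc(Cl)c3)ccc12`, 0%

Compound 1 is `CCNC(=O)Nc1cc(=O)oc2cc(OCc3cccc(Cl)c3)ccc12`; in an assay on isolated protein (strain Sprague-Dawley) for inhibition of Amine oxidase [flavin-containing] A (Rattus norvegicus), read by spectrophotometry, with a stated time of 5 min, tested at 10 uM (on this read-out lower numbers stand for less inhibition and higher numbers for more inhibition at the one concentration tested (going by the name of the read-out)), compound 1 gives 0%. Compound 2 is `CC(=O)c1cc(=O)oc2cc(OCc3cccc(Cl)c3)ccc12`; in this assay compound 2 gives 0%. The single measured step, no change at the digits printed from compound 1 to compound 2 (within the scatter), exchanges an (ethylcarbamoyl)amino group for an acetyl group on an aromatic carbon, and both compounds sit at the floor of the read-out, so compound 2 is level with compound 1 at the digits shown.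

Compound 3 is `O=Cc1cc(=O)oc2cc(OCc3cccc(Cl)c3)ccc12`. It differs from compound 2 by hydrogen in place of methyl on a carbonyl carbon: the change leaves the carbonyl carbon in place and only trims the methyl away, so acetyl becomes formyl. Among the compounds with values here, no measured step touches this carbonyl, so the only guide is that compound 1 and compound 2 both show no inhibition. Neither the larger swap from compound 1 to compound 2 nor anything else here moved the read-out, and the present change is smaller. Compound 3 is therefore expected to stay at the floor, with no change at the digits printed from compound 2 to compound 3 (within the scatter) as the estimated step. The estimate for compound 3 is 0%, expected to fall between 0% and 12%.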

Compound 3, a percentage reported as inhibition, at one concentration (the size of the read-out at that concentration, not a potency): 14%
The estimate for compound 3 lay 14 percentage points below the measured number; measured number outside the range, above it.
By their numbers in this assay, from the lowest: compounds 1 and 2 (each within the scatter of the next); then compound 3.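

In this assay, hydrogen in place of methyl on a carbonyl carbon gives a number 14 percentage points higher from compound 2 to compound 3 (beyond the scatter), which shows that the group on this aromatic carbon can move the read-out, something compounds 1 and 2 could not show with their matching values. The change is small in atoms, since one methyl leaves and no heavy atom enters, yet acetyl and formyl are told apart here, so the read-out responds to a difference of a single carbon on this carbonyl. Formyl in place of (ethylcarbamoyl)amino on the same aromatic carbon gives a number 14 percentage points higher from compound 1 to compound 3 (beyond the scatter), and nothing at hand says why formyl stands apart from the other two groups.

Within the data shown here, with only three compounds, and one concentration for each, these numbers show a modest level of inhibition rather than a potency, and they cannot say how much further this position could go. As far as these compounds go, whether a carboxylic acid, an amine, a hydroxymethyl group or a longer chain on this carbon would give more inhibition, less or the same remains open.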